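A few compounds are considered here, and "the series" means these few. Any claim that something is new, unique, unknown or untested is made for them only; others in the source may bear on it.

Measured so far in an assay on membranes from brain for binding affinity to Adrenergic receptor alpha-1 (Rattus norvegicus); on this read-out lower numbers stand for stronger inhibition and higher numbers for weaker inhibition:
compound 1 `c1ccc(CC2CCN(Cc3nc4ccccc4[nH]3)CC2)cc1` — 2800 nM
compound 2 `c1ccc(Oc2ccc(Cc3nc4ccccc4[nH]3)cc2)cc1` — 4200 nM
compound 3 `Oc1cccc2[nH]c(Cc3ccc(Oc4ccccc4)cc3)nc12` — 5500 nM

In this assay compound 2 holds the second highest of the three numbers. The nearest value is that of compound 3, reached by a step of a 1.3-fold higher number from compound 2 to compound 3 (0.12 log units; within the scatter). Compound 1 gives a lower number than compound 2, and the two values sit within the scatter of one another, so no order between them is claimed.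

Compound 4 `CS(=O)(=O)Nc1ccc2[nH]c(Cc3ccc(Oc4ccccc4)cc3)nc2c1` differs from compound 2 by methanesulfonamido in place of hydrogen on an aromatic carbon. Within the data shown here, the only measured step that bears on a substituent entering the fused ring of this core is the one from compound 2 to compound 3, which stayed within the scatter. Methanesulfonamido is a larger group than hydroxy, and no measured compound carries it, so the precedent is indirect; on the sole comparison available no movement beyond the scatter is expected in this assay.

Compound 4 is therefore estimated at 4000 nM, with a range from 1500 nM to 11000 nM. The expected step is a 1.1-fold lower number from compound 2 to compound 4 (0.02 log units; within the scatter), none beyond the scatter.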

Compound 4, half-maximal inhibitory concentration: 4000 nM
Compound 4: the middle estimate sits on the measured number at the digits printed; low and high end bracket the measured number.
By their numbers in this assay, from the lowest: compounds 1, 4, 2 and 3 (each within the scatter of the next).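

In this assay, the step of a 1.1-fold lower number from compound 2 to compound 4 (0.02 log units; within the scatter) shows that this aromatic carbon, meta to a fused ring and para to a fused ring, takes methanesulfonamido, with 5 heavy atoms, without a reading beyond the scatter. Until now, the only substituent on the fused system of this core was hydroxy, with the step of a 1.3-fold higher number from compound 2 to compound 3 (0.12 log units; within the scatter), so tolerance had been seen only for a single small group, and at another place on the ring. No evidence on hand accounts for this flat reading.

Going by these compounds, whether a carboxylic acid or a primary amine on the same carbon would also stay within the scatter remains open. All four values lie within the scatter of their neighbours, so the compounds shown do not reveal any change that moves this number.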